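The source may report more compounds than this note shows. Statements on the series, on what has been measured and on what is new or still open speak of the compounds shown alone.

Compound 1 `O=C(N[C@@H]1COc2nc([N+](=O)[O-])cn2C1)c1ccc(OC(F)(F)F)cc1` and compound 2 `CN(C(=O)c1ccc(OC(F)(F)F)cc1)[C@@H]1COc2nc([N+](=O)[O-])cn2C1` share one core, and in a physicochemical assay for solubility, read by HPLC, measured as kinetic solubility, at pH 7 (on this read-out higher numbers stand for higher solubility and lower numbers for lower solubility), compound 1 gives 109 ug/mL, while compound 2 gives 17 ug/mL. The change between them is methyl in place of hydrogen on an amide-type nitrogen and it made a step of a 6.4-fold lower number from compound 1 to compound 2 (0.81 log units; beyond the scatter). Compound 3 `O=C(Nc1ccc(OC(F)(F)F)cc1)O[C@@H]1COc2nc([N+](=O)[O-])cn2C1` is built on another core; the difference between the two cores is not broken down here. In this assay compound 3 gives 5.4 ug/mL, the lowest of the three numbers. Compound 4 `CN(C(=O)O[C@@H]1COc2nc([N+](=O)[O-])cn2C1)c1ccc(OC(F)(F)F)cc1` has not yet been measured. It differs from compound 3 by methyl in place of hydrogen on an amide-type nitrogen. This is the same kind of change as that from compound 1 to compound 2, though the surroundings of the place differ: in compound 1 the other neighbours of the nitrogen are a carbonyl carbon and a saturated ring carbon, whereas in compound 3 they are an aromatic carbon and a carbonyl carbon. A step in the same direction, perhaps somewhat smaller, is expected, and compound 4 is expected to come out near 2 ug/mL, most likely within 0.7 ug/mL to 6 ug/mL. That expectation rests on the step of a 6.4-fold lower number from compound 1 to compound 2 (0.81 log units; beyond the scatter). The expected step would be a 2.7-fold lower number from compound 3 to compound 4 (0.43 log units; beyond the scatter).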

Compound 4, solubility: 18 ug/mL
Beside the measured number, compound 4's estimate is 9.0-fold (0.95 log units) below it; measured number outside the range, above it.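

In this assay the same change, methyl in place of hydrogen on an amide-type nitrogen, gave a 3.3-fold higher number from compound 3 to compound 4 (0.52 log units; beyond the scatter) while on the other core it gave a 6.4-fold lower number from compound 1 to compound 2 (0.81 log units; beyond the scatter) and so the two steps, each beyond the scatter, run in opposite directions. The direction seen on one core therefore did not carry over to the other, but a single pair on each core cannot show whether the core as a whole, the other neighbours of the nitrogen, or something else sets that direction. Nothing available here bears on why the two steps differ.

The compounds shown leave open whether a longer chain, such as ethyl, in place of the same hydrogen would follow the methyl step on either core. They also leave open whether an amine or a carboxylic acid carried on that chain would give steps of the same direction on both cores.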